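Changing the aryl group on the amide nitrogen

The source may report more compounds than this note shows. Statements on the series, on what has been measured and on what is new or still open speak of the compounds shown alone.

Measured compounds:
compound 1, `COc1ccc(CNC(=O)/C=C/c2coc3cc(O)ccc3c2=O)cc1`, 8430 nM
compound 2, `COc1cccc(NC(=O)/C=C/c2coc3cc(OC)ccc3c2=O)c1`, 11100 nM

Of the compounds shown here, two have been measured in a functional assay on Huh-7 cells (Homo sapiens) for inhibition, read by MTT assay, with a stated time of 48 h; on this read-out higher numbers stand for weaker inhibition and lower numbers for stronger inhibition. Compound 1, `COc1ccc(CNC(=O)/C=C/c2coc3cc(O)ccc3c2=O)cc1`, gives 8430 nM. Compound 2, `COc1cccc(NC(=O)/C=C/c2coc3cc(OC)ccc3c2=O)c1`, gives 11100 nM. Compound 2 has the higher of the two numbers, but the gap to compound 1 lies within the usual scatter of repeated measurements, so the two cannot be told apart on these data.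

Compound 3, `COc1ccc2c(=O)c(/C=C/C(=O)Nc3ccc(C)cc3)coc2c1`, has not yet been measured in this assay. It differs from compound 2 in one place: 4-methylphenyl in place of 3-methoxyphenyl on an amide-type nitrogen. Among the measured compounds shown here, no step between measured compounds of the same kind is known, so there is nothing to lean on beyond the two values themselves, which sit close together.

With so little to go on, the expected step from compound 2 to compound 3 is a 1.2-fold lower number from compound 2 to compound 3 (0.07 log units; within the scatter), that is, none beyond the scatter in either direction. Compound 3 is therefore estimated at 9500 nM in this assay, with a range from 3500 nM to 28000 nM.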

Compound 3, half-maximal inhibitory concentration: > 100000 nM
Compound 3: a limit, no number; the forecaster's own chance of this, stated with the estimate: 10%; at least 10-fold (1.02 log units) between middle value and limit.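

In this assay, the amide nitrogen proves not to be a place where one aryl group can simply stand in for another: putting 4-methylphenyl in place of 3-methoxyphenyl gives an at least 9.0-fold higher number from compound 2 to compound 3 (0.95 log units; beyond the scatter). Compound 1 and compound 2 differ in more than one place, so their close values could not reveal how much this single position matters. The full size of the step remains unknown, as compound 3 carries a limit of the assay and not a number: the limit of > 100000 nM in this assay, at which 1 of the 3 values shown sits.

This single change replaces the methoxy group with a methyl group and also moves the substituent to a different place on the phenyl ring, so the compounds shown cannot tell which of the two differences goes with the loss of activity. A 3-methylphenyl group on the same amide nitrogen would separate these two differences, while an unsubstituted phenyl group or a phenyl ring carrying a carboxylic acid would show how the position responds to other groups.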